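Chloro and methyl replace isopropyl on the outer ring

The source may hold more compounds than are shown below. What is called first, only, known or untested is meant among the compounds shown, and "the series" means these compounds.

The measured compounds:
compound 1, `O=C(O)CS(=O)(=O)c1ccc(OCc2cccc(-c3ccccc3)c2)cc1`, 288 nM in a functional assay on CHO cells for agonist activity at Free fatty acid receptor 1 (Homo sapiens), read by FLIPR and calcium flux; a higher number here means that more compound is needed for the effect, a lower number that less compound is needed
compound 2, `O=C(O)CS(=O)(=O)c1ccc(OCc2cccc(-c3ccccc3Cl)c2)cc1`, 28.8 nM
compound 3, `CC(C)c1ccccc1-c1cccc(COc2ccc(S(=O)(=O)CC(=O)O)cc2)c1`, 74.1 nM

Compound 3 stands second highest of the three numbers in this assay: its nearest neighbour is compound 2, with a 2.6-fold higher number from compound 2 to compound 3 (0.41 log units; beyond the scatter), and the furthest is compound 1, with a 3.9-fold lower number from compound 1 to compound 3 (0.59 log units; beyond the scatter).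

Compound 4, `Cc1ccc(-c2cccc(COc3ccc(S(=O)(=O)CC(=O)O)cc3)c2)c(Cl)c1`, has not been measured. It differs from compound 3 in one place: 2-chloro-4-methylphenyl in place of 2-isopropylphenyl on an aromatic carbon.

Among the measured compounds shown here, two measured steps bear on this. The step of a 10-fold lower number from compound 1 to compound 2 (1.00 log units; beyond the scatter) shows what a chloro on that ring does to the number, and the step of a 2.6-fold higher number from compound 2 to compound 3 (0.41 log units; beyond the scatter) shows that exchanging that chloro for isopropyl moves the number back up. Compound 4 restores the chloro of compound 2 and adds a methyl. For the measured compounds named here, the methyl has no measured counterpart here, so the expectation rests on the chloro alone: a lower number than compound 3, near compound 2. For compound 4 the estimated change is a 3.0-fold lower number from compound 3 to compound 4 (0.47 log units; beyond the scatter), and the estimated value is 25 nM, with a range from 8 nM to 80 nM.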

Compound 4, half-maximal effective concentration: 36.3 nM
Compound 4: middle estimate off by 1.5-fold (0.16 log units), on the low side; the measured number falls inside the stated range.
By their numbers in this assay, from the lowest: compounds 2 and 4 (each within the scatter of the next); then compound 3; then compound 1.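

In this assay, adding the methyl of 2-chloro-4-methylphenyl to the chloro-bearing ring gives a 1.3-fold higher number from compound 2 to compound 4 (0.10 log units; within the scatter), so this ring accepts a methyl with no shift that can be told from the scatter. The lower number brought by the chloro persists with the methyl present, with a 7.9-fold lower number from compound 1 to compound 4 (0.90 log units; beyond the scatter), and the exchange of 2-isopropylphenyl for the new ring gives a 2.0-fold lower number from compound 3 to compound 4 (0.31 log units; beyond the scatter). No measurement is at hand that accounts for these differences.

The compounds shown leave open whether a methoxy, an amine or a trifluoromethyl in the place of that methyl would be accepted in the same way. They also leave open what a methyl does on the outer ring without the chloro, and whether a fluoro or a bromo could stand in for the chloro.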